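Half-life after a 1-aminocyclopropyl replacement

The source may hold more compounds than are shown below. What is called first, only, known or untested is meant among the compounds shown, and "the series" means these compounds.

Of the compounds shown here, two sharing one core have been measured in an in vitro ADME assay on microsomes (Mus musculus) for metabolic stability; on this read-out higher numbers stand for a longer-lived compound and lower numbers for a shorter-lived compound. Compound 1 `Cc1c2c(n3c1CCN(C(=O)[C@@H](N)C(C)C)C[C@@H](C)[C@H](C)Nc1cc-3ccc1C(N)=O)CC(C)(C)CC2=O` gives 0.133 h, and compound 2 `Cc1c2c(n3c1CCN(C(=O)C(C)(C)N)C[C@@H](C)[C@H](C)Nc1cc-3ccc1C(N)=O)CC(C)(C)CC2=O` gives 0.367 h, the higher of the two numbers. Going by the values given here, the one measured step, a 2.8-fold higher number from compound 1 to compound 2 (0.44 log units; beyond the scatter), is modest but beyond the usual scatter. It puts 1-amino-1-methylethyl in place of 1-amino-2-methylpropyl on a carbonyl carbon.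

Compound 3 `Cc1c2c(n3c1CCN(C(=O)C1(N)CC1)C[C@@H](C)[C@H](C)Nc1cc-3ccc1C(N)=O)CC(C)(C)CC2=O` changes the same group again, with 1-aminocyclopropyl in place of 1-amino-1-methylethyl on a carbonyl carbon. The step to compound 2 bears on this only in part. It concerns the same place, but neither of its groups has a ring, so the data do not show what a three-membered ring brings. The expectation therefore starts from compound 2 at 0.367 h, and no step beyond the scatter is expected in this assay. The expected change is a 1.1-fold higher number from compound 2 to compound 3 (0.04 log units; within the scatter). The estimate for compound 3 is 0.4 h, with an expected range from 0.18 h to 0.85 h.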

Compound 3, half-life: > 0.5 h
Compound 3 gave a limit, no number; the forecaster's own chance of this, stated with the estimate: 2%; middle value at least 1.2-fold (0.09 log units) away from the limit.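

In this assay compound 3 gives > 0.5 h, which is a limit and not a number, and it stands alone at that limit among the three compounds: the limit of > 0.5 h in this assay, at which 1 of the 3 values shown sits.

At this position, on a carbonyl carbon whose other neighbour is an amide-type nitrogen in a ring, the first group carrying a ring shows no sign of a shorter half-life, with an at least 1.3-fold higher number from compound 2 to compound 3 (0.13 log units; that floor lies within the scatter). That floor alone does not separate the 1-aminocyclopropyl group from 1-amino-1-methylethyl, whereas the comparison with 1-amino-2-methylpropyl is clear, at an at least 3.7-fold higher number from compound 1 to compound 3 (0.57 log units; beyond the scatter), so the change to a three-membered ring keeps a gain beyond the scatter over the group of the lowest compound.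

Going by these compounds, how far the true half-life lies past the limit remains unknown, and with it whether the step from 1-amino-1-methylethyl to 1-aminocyclopropyl is a real one or falls within the scatter. Whether 1-aminocyclobutyl, with a larger ring, or a methylamino group on the cyclopropane ring in place of the free amine would behave in the same way is also left open.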